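Swapping 3,4-dimethoxyphenyl for 2-chlorophenyl

The source may hold more compounds than are shown below. What is called first, only, known or untested is meant among the compounds shown, and "the series" means these compounds.

Measured so far in a functional assay on the whole organism (strain Kunming) with Mus musculus as the target, with a stated time of 0.5 h; on this read-out lower numbers stand for an effect already at smaller amounts and higher numbers for an effect only at larger amounts of compound:
- Compound 1 `COc1cc(OC)c(OC)cc1/C=C/COC(=O)/C=C/c1ccc(OC)c(OC)c1` gives 140 umol/kg
- Compound 2 `COc1cc(OC)c(OC)cc1/C=C/COC(=O)/C=C/c1ccc(OC)c(OC)c1OC` gives 75.1 umol/kg

Going by the values given here, these are the only two numbers available, and compound 1 stands within the scatter of compound 2. Compound 3 `COc1cc(OC)c(OC)cc1/C=C/COC(=O)/C=C/c1ccccc1Cl` has not yet been measured. Its difference from compound 1 is 2-chlorophenyl in place of 3,4-dimethoxyphenyl on a double-bonded chain carbon bound to a double-bonded chain carbon and, in words, it is 2-chlorophenyl in place of 3,4-dimethoxyphenyl on a double-bonded chain carbon bound to a double-bonded chain carbon. Among the compounds with values here, one measured step touches the same group: compound 2 carries an added methoxy there, and the step is a 1.9-fold lower number from compound 1 to compound 2 (0.27 log units; within the scatter) in size. Within the data shown here, no measured compound shows what chlorine does or what losing both methoxy groups does. No step beyond the scatter is therefore expected in this assay and no direction is favoured, though the uncertainty is wide. The expected step is a 1.3-fold lower number from compound 1 to compound 3 (0.10 log units; within the scatter) as an estimate. Compound 3 is expected at 110 umol/kg with an estimated range from 40 umol/kg to 280 umol/kg in this assay.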

Compound 3, dose for half-maximal effect: 151 umol/kg
Compound 3: middle estimate off by 1.4-fold (0.14 log units), on the low side; the range from low to high includes it.
By their numbers in this assay, from the lowest: compounds 2, 1 and 3 (each within the scatter of the next).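

Swapping 3,4-dimethoxyphenyl for 2-chlorophenyl on the double-bonded chain carbon comes out in this assay as a 1.1-fold higher number from compound 1 to compound 3 (0.03 log units; within the scatter). Going by these compounds alone, the earlier pair showed only that adding one methoxy group stays within the scatter, whereas compound 3 shows the same for a much larger change: both methoxy groups are gone, a chlorine has come in, and the entering group carries no hydrogen-bond acceptors, so in this assay the methoxy groups of compound 1 are not needed for a number of this size. No supporting measurement is available to explain this result.

A plain phenyl ring would be needed to separate the contribution of the chlorine from the loss of the methoxy groups. On these data alone, it also remains open whether a different kind of group at this place, such as an amine or a carboxylic acid, would give a step beyond the scatter.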